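Methyl on the ring amide nitrogen of compound 2

The source may report more compounds than this note shows. Statements on the series, on what has been measured and on what is new or still open speak of the compounds shown alone.

In a functional assay on the whole organism for agonist activity, with Mus musculus as the target (on this read-out higher numbers stand for an effect only at larger amounts of compound and lower numbers for an effect already at smaller amounts), compound 1 `O=C1NCCN1CC#CCn1ccnc1` reads 17.3 mg/kg and compound 2 `CN(C)CC#CCN1CCNC1=O` reads 9.7 mg/kg on the numbers shown, so compound 2 stands level with compound 1 within the scatter. Compound 3 `CN(C)CC#CCN1CCN(C)C1=O` carries methyl in place of hydrogen on an amide-type nitrogen in a ring, with methyl in place of hydrogen on an amide-type nitrogen in a ring as the change. For the measured compounds named here, the only measured step is a 1.8-fold lower number from compound 1 to compound 2 (0.25 log units; within the scatter) and it concerns dimethylamino in place of 1H-imidazol-1-yl on a saturated chain carbon, not this nitrogen. Going by the values given here, with no measured step at this nitrogen, the expected step is a 1.2-fold higher number from compound 2 to compound 3 (0.09 log units; within the scatter) and nothing beyond the scatter is foreseen. For this assay compound 3 is estimated at 12 mg/kg within an expected range of 3 mg/kg to 45 mg/kg for now.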

Compound 3, dose for half-maximal effect: 0.54 mg/kg
For compound 3 the middle estimate is 22-fold (1.35 log units) above the measured one; the measured number lies below the stated range.
By their numbers in this assay, from the lowest: compound 3; then compounds 2 and 1 (each within the scatter of the next).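

In this assay the amide-type nitrogen in the ring proves a sensitive position: methyl in place of hydrogen gives an 18-fold lower number from compound 2 to compound 3 (1.25 log units; beyond the scatter) and so moves the read-out beyond the scatter, whereas dimethylamino in place of 1H-imidazol-1-yl gave only a 1.8-fold lower number from compound 1 to compound 2 (0.25 log units; within the scatter) on the same read-out. In this pair the amide hydrogen is not required for an effect at smaller amounts of compound. No evidence on the origin of this step is available. Still open, from the compounds shown here alone, is whether ethyl or a longer chain on this nitrogen behaves like methyl, and whether the same change holds with 1H-imidazol-1-yl on the chain.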